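The compounds below may be only part of what the source reports. "The series", "measured", "known", "first", "only" and "open" are said of these compounds alone.

Working notes on the amide series in a functional assay on MCF7 cells (Homo sapiens) for cytotoxicity, read by MTT assay, with a stated time of 48 h; a higher number here means a weaker inhibitor, a lower number a stronger inhibitor. Compound 1 `COc1ccc(NC(=O)c2cn(-c3ccccc3)nc2-c2ccccc2)cc1` gives 1710 nM in this assay. Compound 2 `Cc1ccc(-c2nn(-c3ccccc3)cc2C(=O)Nc2ccccc2)cc1` gives 2450 nM, and compound 3 `O=C(Nc1ccccc1)c1cn(-c2ccccc2)nc1-c1ccc(Cl)cc1` gives 2340 nM. The three numbers sit within the scatter of one another: compound 3 lies nearest to compound 2, and its gap to compound 1 is also within the scatter, so no ordering among the three can be read from these data. Among the measured compounds shown here, the one single-place step measured so far, a 1.0-fold lower number from compound 2 to compound 3 (0.02 log units; within the scatter), is flat, a chloro in place of methyl on an aromatic carbon leaving the number essentially unchanged.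

Compound 4 `CCOc1ccc(NC(=O)c2cn(-c3ccccc3)nc2-c2ccc(Cl)cc2)cc1` is the next member. Relative to compound 3 the change is ethoxy in place of hydrogen on an aromatic carbon of the anilino ring, para to a large group. For the measured compounds named here, no measured pair covers an alkoxy group on that ring as a sole change; compound 1 carries methoxy there but differs from compound 3 at two places, and its value lies within the scatter of compound 3. Going by the values given here, with the only measured step, a 1.0-fold lower number from compound 2 to compound 3 (0.02 log units; within the scatter), showing nothing beyond the scatter, the step of a 1.2-fold lower number from compound 3 to compound 4 (0.09 log units; within the scatter) is expected to stay within the scatter as well. Compound 4 is estimated at 1900 nM, with a range of 750 nM to 4800 nM.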

Compound 4, half-maximal inhibitory concentration: 560 nM
Estimate against measurement, compound 4: 3.4-fold (0.53 log units) above; the whole stated range lies above it.
By their numbers in this assay, from the lowest: compound 4; then compounds 1, 3 and 2 (each within the scatter of the next).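

In this assay, among the compounds shown here, the anilino ring is the first place where a single change moves the number beyond the scatter, with a 4.2-fold lower number from compound 3 to compound 4 (0.62 log units; beyond the scatter) on putting ethoxy in place of hydrogen on an aromatic carbon, para to a large group. For the compounds shown here, the only earlier single-place step, a 1.0-fold lower number from compound 2 to compound 3 (0.02 log units; within the scatter) for chloro in place of methyl, was flat, so the series is not insensitive to every change, although the size of the new step is only modest and it rests on one pair. No measurement at hand bears on why this ethoxy group lowers the number.

Going by these compounds, whether the drop belongs to ethoxy in particular or would follow from other groups at this place remains open, and methoxy, a longer chain such as butoxy, a halogen such as fluoro or an amine such as dimethylamino, each placed on the core of compound 3, would test this. On these data alone, it is also open whether ethoxy gives a step of similar size with methyl in place of chloro, as on the core of compound 2.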